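The source may report more compounds than this note shows. Statements on the series, on what has been measured and on what is new or still open speak of the compounds shown alone.

Three related compounds have been tested in a functional assay on cells (Erythrocyte, Homo sapiens); a higher number here means a weaker inhibitor, a lower number a stronger inhibitor. Compound 1 `COc1cc(CS(=O)(=O)c2nc3ccccc3[nH]2)ccc1OCc1nccc(OCC(F)(F)F)c1C` gives 1310 nM. Compound 2 `COc1ccc2[nH]c(S(=O)(=O)Cc3ccc(OCc4nccc(OC)c4OC)c(OC)c3)nc2c1` gives 898 nM, and compound 3 `COc1ccc2[nH]c(S(=O)(=O)Cc3ccc(OCc4nccc(OCC(F)(F)F)c4C)c(OC)c3)nc2c1` gives 1760 nM. All three numbers lie within the usual scatter of one another, so none of the compounds can be called stronger or weaker than the others on this evidence.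

Compound 3 and compound 1 differ in a single place: hydrogen in place of methoxy on an aromatic carbon. That change produced a 1.3-fold lower number from compound 3 to compound 1 (0.13 log units; within the scatter). Compound 2 and compound 3 differ in more than one place, and the difference between the two cores is not broken down here.

Compound 4 `COc1cc(CS(=O)(=O)c2nc3ccccc3[nH]2)ccc1OCc1nccc(OC)c1OC` has not yet been measured. It is made from compound 2 by the same change that turned compound 3 into compound 1: hydrogen in place of methoxy on an aromatic carbon. The expectation rests on that earlier pair, because the step there was a 1.3-fold lower number from compound 3 to compound 1 (0.13 log units; within the scatter), a small one, and the same small step is expected here, a 1.3-fold lower number from compound 2 to compound 4 (0.11 log units; within the scatter). Compound 4 is therefore expected to give about 700 nM in this assay, most likely between 350 nM and 1400 nM.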

Compound 4, half-maximal inhibitory concentration: 212 nM
The estimate for compound 4 lay 3.3-fold (0.52 log units) above the measured number, outside the stated range (below it).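

In this assay, replacing the methoxy group with hydrogen, which turns 5-methoxy-1H-benzimidazol-2-yl into 1H-benzimidazol-2-yl, gave a 4.2-fold lower number from compound 2 to compound 4 (0.63 log units; beyond the scatter), a modest but real gain in potency. The size of this effect therefore did not carry over unchanged from one core to the other: the same change on two cores in this assay, a 1.3-fold lower number (0.13 log units; within the scatter) from compound 3 to compound 1 and a 4.2-fold lower number (0.63 log units; beyond the scatter) from compound 2 to compound 4, 3.2-fold (0.50 log units) apart, beyond the scatter of two such steps

So a step measured on one core in this series cannot simply be copied onto another, even when the change itself is identical. For the compounds shown here, with only two pairs, however, this does not show what sets the size of the step, nor how large it would be on a third core.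

The compounds shown leave open whether the larger step belongs to the dimethoxy-substituted core of compound 2 alone or would also appear on other cores. They also leave open how other groups at this place on the aromatic ring, such as a chlorine atom, an amine or a carboxylic acid, would compare with hydrogen and methoxy.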